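Positional shift of trifluoromethyl on the aryl piperazine

This account rests on a few compounds, and the source may have more. Where it says the series, first, only, none or still open, it means among the compounds named here.

Two members of this series have been measured in an assay on HEK293 cells for inhibition of Voltage-dependent T-type calcium channel subunit alpha-1G (Homo sapiens), read by fluorescence, tested at 10 uM; a higher number here means more inhibition at the concentration tested (going by the name of the read-out), a lower number less inhibition. Compound 1 `CCCc1nc(-c2ccccc2)c(CNCCN2CCN(c3cccc(C(F)(F)F)c3)CC2)o1` gives 56.3% in this assay. Compound 2 `CCCc1nc(-c2ccccc2)c(CNCCCN2CCN(c3cccc(Cl)c3)CC2)o1` gives 65.9% in this assay, and the gap between compound 1 and compound 2 lies within the usual scatter, so the two numbers are read as one level rather than as a difference. Going by the values given here, no pair of measured compounds differs in a single place, so no measured step is available to calibrate the change now under consideration.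

Compound 3 `CCCc1nc(-c2ccccc2)c(CNCCN2CCN(c3ccc(C(F)(F)F)cc3)CC2)o1` is yet to be measured in this assay. It differs from compound 1 as follows: 4-(trifluoromethyl)phenyl in place of 3-(trifluoromethyl)phenyl on an amine nitrogen in a ring. Among the compounds with values here, with no measured step to lean on, the expectation is that the change from compound 1 to compound 3 stays within the scatter, in no particular direction, giving an estimated step of a number 1.3 percentage points lower from compound 1 to compound 3 (within the scatter). Compound 3 is thus expected to reach about 55% in this assay, with a range of 35% to 75%.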

Compound 3, a percentage reported as inhibition, at one concentration (the size of the read-out at that concentration, not a potency): 58.7%
For compound 3 the middle estimate is 3.7 percentage points below the measured one; low and high end bracket the measured number.
By their numbers in this assay, from the lowest: compounds 1, 3 and 2 (each within the scatter of the next).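

Placing the trifluoromethyl group as 4-(trifluoromethyl)phenyl instead of 3-(trifluoromethyl)phenyl on the amine nitrogen of the ring gives the only single-place step in the series so far: in this assay the step is a number 2.4 percentage points higher from compound 1 to compound 3 (within the scatter) and so gives no sign that this shift matters. Compound 1 and compound 3 therefore read as one level, so at this position either placement of trifluoromethyl on the phenyl ring is compatible with that level of inhibition. Nothing available explains why the two placements read alike.

Still open, from the compounds shown here alone, is how a nitrile or a carboxylic acid in place of trifluoromethyl on this phenyl ring would read in this assay. Also open, going by these compounds, is whether the same positional shift would read alike on the chain carried by compound 2.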